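The source may hold more compounds than are shown below. What is called first, only, known or untested is meant among the compounds shown, and "the series" means these compounds.

Among the compounds with values here, compound 1 `CCOC(=O)/C=C(C)/C=C/CC(C)CCCC(C)(C)OC` gives 5.54 in a physicochemical assay for lipophilicity (a higher number here means a more lipophilic compound, a lower number a more polar compound), the lowest of the three numbers measured so far. Compound 2 `CCOC(=O)/C=C(C)/C=C/CC(C)CCCC(C)(C)Cl` gives 6.44 and compound 3 `CCOC(=O)/C=C(C)/C=C/CC(C)CCCC(C)CC` gives 7.81. The measured steps of a number 0.90 log units higher from compound 1 to compound 2 (beyond the scatter), a number 2.27 log units higher from compound 1 to compound 3 (beyond the scatter) and a number 1.37 log units higher from compound 2 to compound 3 (beyond the scatter) all concern the saturated chain carbon bound to three saturated chain carbons, and none alters the carbonyl carbon. Compound 4 `COC(C)(C)CCCC(C)C/C=C/C(C)=C/C(=O)N(C)C` keeps that chain end unchanged and differs from compound 1 only at the carbonyl carbon: dimethylamino in place of ethoxy on a carbonyl carbon. Within the data shown here, no measured step bears on a change of ethoxycarbonyl to dimethylcarbamoyl, so the series offers no direct calibration. Nevertheless a step downward, beyond the scatter, is expected: a number 1.34 log units lower from compound 1 to compound 4 (beyond the scatter). For compound 4 the estimated value is 4.2, with a range from 3.5 to 4.9.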

Compound 4, partition coefficient: 3.74
Compound 4: the middle estimate sits 0.46 log units above what was measured; the range from low to high includes it.
By their numbers in this assay, from the lowest: compound 4; then compound 1; then compound 2; then compound 3.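

In this assay, dimethylamino in place of ethoxy on a carbonyl carbon gives a number 1.80 log units lower from compound 1 to compound 4 (beyond the scatter), so the read-out also responds to a change at the carbonyl carbon, not only at the chain end. Within the data shown here, this is the first downward step, with the chain end held constant. No measured evidence accounts for the step.

On these data alone, whether this change gives a similar step with the chloro chain end of compound 2 or the sec-butyl chain end of compound 3 remains open. So does the reading for a carboxylic acid or diethylamino group on this carbonyl carbon.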